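The source may report more compounds than this note shows. Statements on the series, on what has been measured and on what is new or still open speak of the compounds shown alone.

Measured so far in a functional assay on HOP-62 cells (Homo sapiens) for inhibition, read by sulforhodamine B assay; on this read-out higher numbers stand for weaker inhibition of growth and lower numbers for stronger inhibition of growth:
Compound 1 `Cc1ccc2[nH]c(-c3ccc(-c4ccc(-c5ccc(N(C)C)cc5)cc4)cc3)nc2c1`: 4230 nM
Compound 2 `COc1cc(-c2ccc(-c3ccc(-c4nc5cc(C)ccc5[nH]4)cc3)cc2)cc(OC)c1OC`: 2370 nM
Compound 3 `FC(F)(F)Oc1ccc(-c2ccc(-c3ccc(-c4nc5ccccc5[nH]4)cc3)cc2)cc1`: 100000 nM

Of these three, compound 3 stands highest at 100000 nM, and its number lies beyond the scatter from those of both other compounds. It is therefore the weakest growth inhibitor of the set in this assay.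

Compound 4 `CN(C)c1ccc(-c2ccc(-c3ccc(-c4nc5ccccc5[nH]4)cc3)cc2)cc1` has not yet been measured. It differs from compound 3 in one place, with dimethylamino in place of trifluoromethoxy on an aromatic carbon, para to a large group (dimethylamino in place of trifluoromethoxy on an aromatic carbon). For the measured compounds named here, no pair of measured compounds shows this change on its own, so its size can only be judged indirectly.

Going by the values given here, the one guide is compound 1, which also carries dimethylamino and gives 4230 nM. On that single comparison, a large downward step beyond the scatter is expected, and a 17-fold lower number from compound 3 to compound 4 (1.22 log units; beyond the scatter) is estimated. For compound 4 the expected value is 6000 nM, with an estimated range from 1800 nM to 40000 nM.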

Compound 4, concentration for 50% growth inhibition: 100000 nM
Compound 4: middle estimate off by 17-fold (1.22 log units), on the low side; measured number above the stated range.
By their numbers in this assay, from the lowest: compounds 2 and 1 (each within the scatter of the next); then compounds 3 and 4 (each within the scatter of the next).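

In this assay, dimethylamino in place of trifluoromethoxy on an aromatic carbon, para to a large group, shows no change at the digits printed from compound 3 to compound 4 (within the scatter), so this exchange does not separate these two compounds on this read-out. The large step lies elsewhere, with hydrogen in place of methyl on an aromatic carbon of the shared core giving a 24-fold higher number from compound 1 to compound 4 (1.37 log units; beyond the scatter), which ties the stronger growth inhibition of compound 1 within this pair to that methyl. No supporting data bear on why either step has the size it has.

Going by these compounds, whether the methyl matters as much alongside trifluoromethoxy stays open, as its step can be read only with dimethylamino in place. Also open, on these data alone, is how an ethyl or a chlorine in place of that methyl, or a primary amine or a carboxylic acid in place of dimethylamino, would stand.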